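Swapping Fluoro for Hydrogen on an Inactive Aryl Alkyne

This account rests on a few compounds, and the source may have more. Where it says the series, first, only, none or still open, it means among the compounds named here.

In a functional assay on HL-60 cells (Homo sapiens) for antiproliferative activity, with a stated time of 72 h (on this read-out higher numbers stand for weaker inhibition and lower numbers for stronger inhibition), compound 1 `CCCCC#Cc1cc([C@@H]2O[C@H](CO)[C@@H](O)[C@H]2O)n2ncnc(N)c12`, which carries a butyl group on its triple bond, gives 400 nM. Compound 2 `Nc1ncnn2c([C@@H]3O[C@H](CO)[C@@H](O)[C@H]3O)cc(C#Cc3ccc(F)cc3)c12` gives > 100000 nM, which is a limit of the assay and not a number. Compound 2 therefore stands at the limit of > 100000 nM in this assay, at which 1 of the 2 values shown sits.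

Going by the values given here, the only measured step is an at least 250-fold higher number from compound 1 to compound 2 (2.39 log units; beyond the scatter). It is large and beyond the scatter, and it puts 4-fluorophenyl in place of butyl on a triple-bonded carbon.

Compound 3 `Nc1ncnn2c([C@@H]3O[C@H](CO)[C@@H](O)[C@H]3O)cc(C#Cc3ccccc3)c12` keeps the aromatic ring but has hydrogen in place of fluoro on an aromatic carbon, para to a large group: hydrogen in place of fluoro on an aromatic carbon. Among the compounds with values here, no measured step tests this exchange directly, so the evidence is indirect. The large loss seen on going to compound 2 at > 100000 nM came with the aromatic ring, which stays in place. Compound 3 is therefore expected to remain much weaker than compound 1, and it may also hit the limit.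

The expected change is small, estimated as an at least 1.6-fold lower number from compound 2 to compound 3 (0.22 log units; that floor lies within the scatter). The estimate for compound 3 is 60000 nM, with an expected range of 8000 nM to 100000 nM.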

Compound 3, half-maximal inhibitory concentration: > 100000 nM
Compound 3 ended at the assay's limit; the forecaster's own chance of this, stated with the estimate: 60%; middle value at least 1.6-fold (0.22 log units) away from the limit.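

In this assay, phenyl in place of butyl on a triple-bonded carbon gives an at least 250-fold higher number from compound 1 to compound 3 (2.39 log units; beyond the scatter), so the large loss does not depend on the fluoro group. The step between compound 2 and compound 3 cannot be read, because both compounds sit at the same limit of the assay: the limit of > 100000 nM in this assay, at which 2 of the 3 values shown sit.

With an aromatic ring on the triple bond, the carbon para to a large group therefore gives no readable response to this exchange, and the two aryl compounds point to the ring itself, not its fluoro group, as what goes with the loss, although two compounds are a narrow base for that reading.

The compounds shown leave open whether a different group at that same carbon of the phenyl ring, such as an amine or a carboxylic acid, would bring activity back into a measurable range. They also leave open whether a cyclohexyl ring or a longer chain than butyl on the triple bond would keep the activity of compound 1 or lose it.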